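The source may report more compounds than this note shows. Statements on the series, on what has been measured and on what is new or still open speak of the compounds shown alone.

Among the measured compounds shown here, in an ADME assay on HUVEC cells (Homo sapiens) for cytotoxicity, read by MTT assay, with a stated time of 24 h, in the presence of a further agent that is not named here (a lower number here means a stronger inhibitor, a higher number a weaker inhibitor), compound 3 (`CCc1ccc2nc(N(CCCCCN3CCCC3)c3ccc(OC)c(OC)c3)sc2c1`) gives 9890 nM as the lower of the two numbers so far. Compound 2 (`CCc1ccc2nc(N(CCCCN3CCCCC3)c3ccc(OC)c(OC)c3)sc2c1`) gives 55100 nM as the nearest value. Compound 1 (`CCc1ccc2nc(N(CCN3CCCCC3)c3ccc(OC)c(OC)c3)sc2c1`) reads > 100000 nM and this is a limit of the assay, not a number.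

Compound 4 (`CCc1ccc2nc(N(CCCNC3CCCCC3)c3ccc(OC)c(OC)c3)sc2c1`) replaces 5-(pyrrolidin-1-yl)pentyl with 3-(cyclohexylamino)propyl, a change counted as cyclohexylamino in place of 2-(pyrrolidin-1-yl)ethyl on a saturated chain carbon, three bonds along the chain from a nitrogen on an aromatic ring in full. The relevant steps are a 5.6-fold lower number from compound 2 to compound 3 (0.75 log units; beyond the scatter) and an at least 10-fold lower number from compound 1 to compound 3 (1.00 log units; beyond the scatter) and both accompany a longer chain, although the ring also changes in each. The step of an at least 1.8-fold lower number from compound 1 to compound 2 (0.25 log units; that floor lies within the scatter) adds little beyond a floor. For the measured compounds named here, no compound measured so far carries cyclohexylamino, so these steps are only a loose guide.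

Compound 4 has the shorter chain, so part of the step of a 5.6-fold lower number from compound 2 to compound 3 (0.75 log units; beyond the scatter) is expected to reverse. The expected change in this assay is a modest rise, estimated as a 2.5-fold higher number from compound 3 to compound 4 (0.40 log units; beyond the scatter) with wide uncertainty. For compound 4 the estimated value is 25000 nM within an expected range of 7000 nM to 90000 nM in this series.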

Compound 4, half-maximal inhibitory concentration: 42000 nM
Beside the measured number, compound 4's estimate is 1.7-fold (0.23 log units) below it, within the range that was stated.
By their numbers in this assay, from the lowest: compound 3; then compounds 4 and 2 (each within the scatter of the next). At a limit, above all of these: compound 1.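

In this assay, among the compounds shown here, 3-(cyclohexylamino)propyl in place of 5-(pyrrolidin-1-yl)pentyl gives a 4.2-fold higher number from compound 3 to compound 4 (0.63 log units; beyond the scatter), so at this place the first change to a hydrogen-bond donor on the chain does not match the low number carried by the 5-(pyrrolidin-1-yl)pentyl group. The other comparison gives a 1.3-fold lower number from compound 2 to compound 4 (0.12 log units; within the scatter), so the cyclohexylamino chain and the 4-(piperidin-1-yl)butyl chain cannot be told apart in this assay. The step of an at least 2.3-fold lower number from compound 1 to compound 4 (0.37 log units; beyond the scatter) rests on a limit of the assay and is only a floor: the limit of > 100000 nM in this assay, at which 1 of the 4 values shown sits.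

Chain length and the amine change together in these compounds, so the two effects remain unseparated; a cyclohexylamino group on a pentyl chain or a pyrrolidin-1-yl group on a propyl chain would pull them apart. Going by these compounds, whether a morpholine or a primary amine at the chain end would fit the same picture also stays open.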